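This account rests on a few compounds, and the source may have more. Where it says the series, first, only, none or still open, it means among the compounds named here.

Compound 1 `COc1ccc(-c2cn(C(=O)Nc3cc(OC)c(OC)c(OC)c3)c(=O)n2-c2cc(OC)c(OC)c(OC)c2)cc1O`: > 50000 nM
Compound 2 `COc1cc(-n2c(-c3ccc([N+](=O)[O-])cc3)cn(C(C)=O)c2=O)cc(OC)c1OC`: 49600 nM

Both compounds were tested in a functional assay on A549 cells (Homo sapiens) for cytotoxicity, read by MTT assay, with a stated time of 48 h; a higher number here means a weaker inhibitor, a lower number a stronger inhibitor. Compound 1 is reported only as a limit, > 50000 nM, and not as a true number. For the measured compounds named here, compound 2 gives 49600 nM, the only true number so far, so it has no measured neighbour against which to rank it.

The next compound, compound 3 `COc1ccc(-c2cn(C(C)=O)c(=O)n2-c2cc(OC)c(OC)c(OC)c2)cc1N`, keeps the acetyl group of compound 2. It carries 3-amino-4-methoxyphenyl in place of 4-nitrophenyl on an aromatic carbon. The new group sits on the same carbon of the five-membered aromatic ring with 2 nitrogen.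

Going by the values given here, no measured pair yet shows what a change at this place does, so any forecast here is loose. With compound 2 at 49600 nM, inhibition is already so weak that a change the assay can report as a number is more likely to point towards stronger inhibition. A step of a 9.9-fold lower number from compound 2 to compound 3 (1.00 log units; beyond the scatter) is therefore expected in this assay, with wide uncertainty. For compound 3 the estimated value is 5000 nM, with an expected range from 100 nM to 50000 nM.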

Compound 3, half-maximal inhibitory concentration: 1100 nM
Compound 3: middle estimate off by 4.5-fold (0.66 log units), on the high side; measured number inside the range.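

For the compounds shown here, this is the first measured step at this place: on the aromatic carbon of the five-membered aromatic ring with 2 nitrogen, 3-amino-4-methoxyphenyl in place of 4-nitrophenyl gives a 45-fold lower number from compound 2 to compound 3 (1.65 log units; beyond the scatter) in this assay. The acetyl group and the rest of the structure stay the same, so the group on this carbon clearly matters for this read-out, and the change turns a very weak inhibitor into a much stronger one. The two groups hold the same number of heavy atoms, but the swap changes several things at once, including the loss of the nitro group and the arrival of both an amine and a methoxy group, so this single step cannot say which of these counts.

Compound 1 is reported only as a limit and offers no number for comparison at this place: the limit of > 50000 nM in this assay, at which 1 of the 3 values shown sits.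

Also open, going by these compounds, is how a simple 3-aminophenyl or 4-methoxyphenyl group would read on this carbon, since either would help to separate the part played by the amine from that of the methoxy group.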